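A Methylphenyl Amide in Place of a Pyridinyl Amide

The source may hold more compounds than are shown below. What is called first, only, known or untested is meant among the compounds shown, and "the series" means these compounds.

Measured compounds:
compound 1 `Cc1cccc(NC(=O)CN2CCC(c3ccc(Cl)cc3)CC2)c1`: 115 nM
compound 2 `O=C(CN1CCN(c2ccccn2)CC1)Nc1cccnc1`: 6410 nM
compound 3 `Cc1cccc(NC(=O)CN2CCN(c3cccc4ccccc34)CC2)c1`: 28.4 nM

In an assay on HEK293 cells for displacement of a labelled ligand from D(4) dopamine receptor (Homo sapiens), read by scintillation counting, with a stated time of 60 min (on this read-out higher numbers stand for weaker inhibition and lower numbers for stronger inhibition), compound 2 gives 6410 nM, the highest of the three numbers. Compound 1 gives 115 nM and compound 3 gives 28.4 nM; both of those numbers lie beyond the scatter below compound 2, so compound 2 is the weakest inhibitor of the three on this read-out.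

Compound 4 `Cc1cccc(NC(=O)CN2CCN(c3ccccn3)CC2)c1` has not been measured. It differs from compound 2 in one place: 3-methylphenyl in place of pyridin-3-yl on an amide-type nitrogen. The same 3-methylphenyl group on the amide-type nitrogen is present in compound 1 and in compound 3, which are the two compounds with the lower numbers, while compound 2 is the only one carrying a pyridin-3-yl there. For the measured compounds named here, no pair of measured compounds isolates this single change, so the expectation rests on that comparison alone.

On that basis a large step toward a lower number, beyond the scatter, is expected in this assay for the move from compound 2 to compound 4. Compound 4 is estimated to give 300 nM, within a range of 60 nM to 1500 nM, which corresponds to an expected step of a 21-fold lower number from compound 2 to compound 4 (1.33 log units; beyond the scatter).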

Compound 4, inhibition constant: 212 nM
Beside the measured number, compound 4's estimate is 1.4-fold (0.15 log units) above it; the measured number falls inside the stated range.
By their numbers in this assay, from the lowest: compound 3; then compounds 1 and 4 (each within the scatter of the next); then compound 2.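

With the rest of compound 2 held fixed, the exchange of pyridin-3-yl for 3-methylphenyl on the amide-type nitrogen can now be read on its own: in this assay it gives a 30-fold lower number from compound 2 to compound 4 (1.48 log units; beyond the scatter), a large step beyond the scatter. The earlier compounds shown here could only suggest a link between this group and lower numbers, as they also differed elsewhere, whereas this pair shows that the group on the amide-type nitrogen alone can move the number by this much. Nothing shown here accounts for the size of the step.

Going by these compounds, the change removes a ring nitrogen and adds a methyl at once, and whether the step follows one or the other remains open, a question that a plain phenyl on the amide-type nitrogen would help to settle. On these data alone, it is also open whether the step carries over to the cores of compound 1 and compound 3, as neither core appears here with pyridin-3-yl on that nitrogen.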